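From 3-bromophenyl to 3-fluorophenyl in the series

The source may hold more compounds than are shown below. What is called first, only, known or untested is meant among the compounds shown, and "the series" means these compounds.

Of the compounds shown here, three sharing one core have been read: compound 1 (`C/C(=C\CC/C(C)=C/CC[C@@H]1[C@@]2(C)CCC(=O)C(C)(C)[C@H]2CC[C@@]1(C)O)CC/C=C(\C)C(=O)OCc1cn(-c2ccc(F)cc2)nn1`), compound 2 (`C/C(=C\CC/C(C)=C/CC[C@@H]1[C@@]2(C)CCC(=O)C(C)(C)[C@H]2CC[C@@]1(C)O)CC/C=C(\C)C(=O)OCc1cn(C[C@@H]2O[C@H](n3ccc(=O)[nH]c3=O)C[C@H]2O)nn1`) and compound 3 (`C/C(=C\CC/C(C)=C/CC[C@@H]1[C@@]2(C)CCC(=O)C(C)(C)[C@H]2CC[C@@]1(C)O)CC/C=C(\C)C(=O)OCc1cn(-c2cccc(Br)c2)nn1`). In a functional assay on U-87MG ATCC cells for antiproliferative activity against U-87 MG (Homo sapiens), read by MTT assay, with a stated time of 48 h (on this read-out lower numbers stand for stronger inhibition and higher numbers for weaker inhibition), compound 1 gives > 150000 nM, which is a limit of the assay and not a number. In this assay compound 3 gives 8750000 nM, the highest of the two true numbers. The nearest, compound 2 at 75800 nM, is far lower, a gap beyond the scatter.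

Compound 4 (`C/C(=C\CC/C(C)=C/CC[C@@H]1[C@@]2(C)CCC(=O)C(C)(C)[C@H]2CC[C@@]1(C)O)CC/C=C(\C)C(=O)OCc1cn(-c2cccc(F)c2)nn1`) differs from compound 3 by fluoro in place of bromo on an aromatic carbon, meta to a large group.

Within the data shown here, the one measured step bearing on this change is a step that the limit leaves unreadable from compound 1 to compound 3, with 3-bromophenyl in place of 4-fluorophenyl on an aromatic nitrogen. It offers no size to carry over. Among the measured compounds shown here, compound 1, the only measured compound with a fluorophenyl group, stands at the limit of > 150000 nM in this assay, at which 1 of the 3 values shown sits, so a lower number than that of compound 3 is expected, though with little support. The expected step is a 35-fold lower number from compound 3 to compound 4 (1.54 log units; beyond the scatter), a move toward stronger inhibition, and its size is uncertain. For compound 4 the estimated value in this assay is 250000 nM, with an expected range of 50000 nM to 2000000 nM.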

Compound 4, half-maximal inhibitory concentration: > 150000 nM
Compound 4: no number, only a limit; the forecaster's own chance of this, stated with the estimate: 45%; the middle value lies beyond the limit too.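

In this assay compound 4 gives > 150000 nM as a limit of the assay and not a number. The steps to compound 4 from compound 3 and from compound 1 therefore cannot be read: the limit of > 150000 nM in this assay, at which 2 of the 4 values shown sit.

As far as these compounds go, what stays open is the size of any change from bromo to fluoro, and whether 3-fluorophenyl and 4-fluorophenyl differ at all.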